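Series notes: cyano in place of nitro, cytotoxicity

The compounds below may be only part of what the source reports. "The series", "measured", "known", "first", "only" and "open" are said of these compounds alone.

Compound 3 `O=[N+]([O-])c1ccc(NC(=S)Nc2cccc(C(F)(F)F)c2)cc1` is measured in an ADME assay on Vero 76 cells (Chlorocebus sabaeus) for cytotoxicity, read by crystal violet staining, with a stated time of 96 h (on this read-out higher numbers stand for lower toxicity in this test and lower numbers for higher toxicity in this test), at 10000 nM. Among the three compounds measured so far, compound 3 stands level with compound 1 `CC[C@H]1CC[C@H](c2ccc(NC(=S)Nc3cccc(C(F)(F)F)c3)cc2)CC1`, which gives 10000 nM in this assay; together these are the two lowest numbers, and no change at the digits printed from compound 1 to compound 3 (within the scatter). The furthest from compound 3 is compound 2 `CCOC(=O)c1ccc(NC(=S)Nc2cccc(C(F)(F)F)c2)cc1`, which in this assay gives 71000 nM; a 7.1-fold lower number from compound 2 to compound 3 (0.85 log units; beyond the scatter), and a 7.1-fold higher number from compound 1 to compound 2 (0.85 log units; beyond the scatter).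

The next compound, compound 4 `N#Cc1ccc(NC(=S)Nc2cccc(C(F)(F)F)c2)cc1`, differs from compound 3 in a single place: cyano in place of nitro on an aromatic carbon. Of the measured steps, two concern exchange of the group on this same aromatic carbon: no change at the digits printed from compound 1 to compound 3 (within the scatter) and a 7.1-fold lower number from compound 2 to compound 3 (0.85 log units; beyond the scatter). For the measured compounds named here, neither involves the cyano group, so the available steps at this carbon span from no change to a modest one, with no direct precedent for cyano itself. The expectation for this assay is therefore a step that stays within the scatter, in no assured direction, a 1.2-fold higher number from compound 3 to compound 4 (0.08 log units; within the scatter). For compound 4 the estimate in this assay is 12000 nM, with a range from 5000 nM to 35000 nM, the width reflecting the modest spread seen across compounds 1, 2 and 3.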

Compound 4, half-maximal cytotoxic concentration: 10000 nM
Compound 4: the middle estimate sits 1.2-fold (0.08 log units) above what was measured; measured number inside the range.
By their numbers in this assay, from the lowest: compounds 1, 3 and 4 (each within the scatter of the next); then compound 2.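

In this assay, for the compounds shown here, the first exchange between the nitro group and the cyano group on this aromatic carbon, para to a large group, leaves the read-out flat: no change at the digits printed from compound 3 to compound 4 (within the scatter), and likewise no change at the digits printed from compound 1 to compound 4 (within the scatter), so 4-ethylcyclohexyl, nitro and cyano now share one level. The ethoxycarbonyl group remains the only one of the four to stand apart, with a 7.1-fold lower number from compound 2 to compound 4 (0.85 log units; beyond the scatter), a step of the same size as the one printed for the nitro group. Nothing on hand bears on why this one group departs from the other three.

Open, from the compounds shown here alone, is whether the higher number of compound 2 stays with an ester of another length, such as a methyl ester, or carries over to a carboxylic acid or an amide on this carbon, and whether an amine or a chlorine atom there would join the level shared by compound 1, compound 3 and compound 4. Also open, going by these compounds, is whether that shared level holds once the trifluoromethyl group of the shared core gives way to another group, such as a methoxy group.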